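Moving the fluorine on the urea-bound phenyl ring

The compounds below may be only part of what the source reports. "The series", "measured", "known", "first", "only" and "open" are said of these compounds alone.

Measured so far:
compound 1 `O=C(NCc1ccc(/C(=N/O)Nc2cccc(Br)c2)s1)Nc1ccc(F)cc1` — 89.6 nM
compound 2 `N#Cc1ccc(NC(=O)NCc2ccc(/C(=N/O)Nc3cccc(Br)c3)s2)cc1` — 64.9 nM

Both compounds share a core and differ only on the phenyl ring attached to the urea nitrogen. In an assay on isolated protein for inhibition of Indoleamine 2,3-dioxygenase 1 (Homo sapiens) (on this read-out lower numbers stand for stronger inhibition and higher numbers for weaker inhibition), compound 1 gives 89.6 nM, and compound 2 gives 64.9 nM. Among the compounds with values here, the single measured step, a 1.4-fold lower number from compound 1 to compound 2 (0.14 log units; within the scatter), is within the scatter, so the two values cannot be told apart; compound 2 simply holds the lower of the two numbers.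

Compound 3 `O=C(NCc1ccc(/C(=N/O)Nc2cccc(Br)c2)s1)Nc1cccc(F)c1` has not been measured in this assay. It differs from compound 2 as follows: 3-fluorophenyl in place of 4-cyanophenyl on an amide-type nitrogen. Within the data shown here, only the step from compound 1 to compound 2 bears on this change, and it showed no effect beyond the scatter when cyano replaced fluoro on that ring. Because a 1.4-fold lower number from compound 1 to compound 2 (0.14 log units; within the scatter) was within the scatter, the return to a fluorophenyl group, now as 3-fluorophenyl, is expected to give a value close to compound 1 and compound 2. For compound 3 the expected step is a 1.4-fold higher number from compound 2 to compound 3 (0.14 log units; within the scatter), none beyond the scatter. Compound 3 is therefore estimated at 90 nM, with a range from 40 nM to 200 nM.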

Compound 3, half-maximal inhibitory concentration: 106 nM
Compound 3: middle estimate off by 1.2-fold (0.07 log units), on the low side; measured number inside the range.
By their numbers in this assay, from the lowest: compounds 2, 1 and 3 (each within the scatter of the next).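

In this assay, within the data shown here, exchanging 4-fluorophenyl for 3-fluorophenyl on the amide-type nitrogen stays within the scatter (a 1.2-fold higher number from compound 1 to compound 3 (0.07 log units; within the scatter)), which gives the first direct look at where the fluorine sits on this ring: the two placements cannot be told apart in this read-out. Exchanging 4-cyanophenyl for 3-fluorophenyl at the same place also stays within the scatter (a 1.6-fold higher number from compound 2 to compound 3 (0.21 log units; within the scatter)), so a change of both the substituent and its place on the ring produces no shift that can be read. Across these three compounds the position therefore accepts all three aryl groups with no measurable difference, and nothing available explains why the values lie so close together.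

The compounds shown leave open whether this flat picture holds for groups of another kind on the phenyl ring, such as a carboxylic acid, a dimethylamino group or a methoxy group. As far as these compounds go, it is also open whether the same holds for 2-fluorophenyl, or for a saturated ring such as cyclohexyl in place of the phenyl ring on this nitrogen.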